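The compounds below may be only part of what the source reports. "The series", "measured", "known", "first", "only" and "open" are said of these compounds alone.

Compound 1 `CCC[C@@H]1O[C@H](COCc2ccccc2)[C@@H](OCc2ccccc2)[C@H](OCc2ccccc2)[C@@H]1O` gives "not active" (no number reported)
Compound 2 `CC(C)C[C@H]1O[C@H](COCc2ccccc2)[C@@H](OCc2ccccc2)[C@H](OCc2ccccc2)[C@@H]1O` gives "not active" (no number reported)
Compound 3 `CCC[C@@H]1O[C@H](COCc2ccccc2)[C@@H](OCc2ccccc2)[C@H](OCc2ccccc2)[C@H]1O` gives 11700 nM

In a functional assay on HL-60 cells (Homo sapiens) for antiproliferative activity, read by MTT assay (on this read-out higher numbers stand for weaker inhibition and lower numbers for stronger inhibition), compound 3 holds the only number shown, 11700 nM, and the other two compounds give none. Given (the fact that compounds 1 and 3 differ only in the configuration as drawn), configuration alone separates a number from none in that pair.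

Compound 4 `CCC[C@H]1O[C@H](COCc2ccccc2)[C@@H](OCc2ccccc2)[C@H](OCc2ccccc2)[C@@H]1O` departs from compound 3 as follows: the two compounds have the same atoms and bonds and differ only in configuration as drawn: 2 of 5 stereo elements differ; a stereocentre at a saturated ring carbon is drawn S in compound 3 and R in compound 4; a stereocentre at a saturated ring carbon is drawn S in compound 3 and R in compound 4.

Going by the values given here, no measured step yet sets the size of such a change in this assay, so any forecast is loose. Compound 1 with "not active" (no number reported) shows that a change of configuration can remove the number, so weaker inhibition is expected, and a report without a number is quite possible. The expected step, a 1.7-fold higher number from compound 3 to compound 4 (0.23 log units; within the scatter), is modest if a number appears. In that case the estimate for compound 4 is 20000 nM, with an expected range from 7000 nM to 60000 nM as its bounds.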

Compound 4, half-maximal inhibitory concentration: "not active" (no number reported)
Compound 4 has no reported number here; no gap can be computed for the estimate.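

In this assay, going by these compounds alone, compound 4 gives "not active" (no number reported), so no step from compound 3 to compound 4 can be read. The compounds shown leave open how large an effect configuration has in numbers, with compound 3 alone holding a value.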